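The source may hold more compounds than are shown below. What is called first, only, known or untested is meant among the compounds shown, and "the series" means these compounds.

Measured compounds:
- compound 1, `Cc1cccc(-c2noc(C3CN(S(=O)(=O)c4ccc(Cl)cc4)C3)n2)c1`: 1100 nM
- compound 2, `Cc1ccc(S(=O)(=O)N2CC(c3nc(-c4cccc(C)c4)no3)C2)cc1`: 670 nM

Both compounds were tested in an assay on HEK293 cells for negative allosteric modulation of metabotropic glutamate receptor 5 (Homo sapiens), read by FLIPR; on this read-out lower numbers stand for stronger inhibition and higher numbers for weaker inhibition. Compound 2 gives the lower of the two numbers, but its gap to compound 1 is small: the step of a 1.6-fold lower number from compound 1 to compound 2 (0.22 log units; within the scatter) stays within the scatter of repeated measurements, so the two values cannot be placed in any order.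

Compound 3, `Cc1cccc(-c2noc(C3CN(S(=O)(=O)c4ccc(F)cc4)C3)n2)c1`, has not yet been measured. It differs from compound 2 at one point only: fluoro in place of methyl on an aromatic carbon.

Within the data shown here, the only measured step that bears on this change is the one from compound 1 to compound 2, where the same position carried chloro and then methyl, and the number moved by a 1.6-fold lower number from compound 1 to compound 2 (0.22 log units; within the scatter), within the scatter. Swapping the group at this position between two small substituents therefore left the number essentially unchanged, and the same is expected here: a step of about a 1.3-fold higher number from compound 2 to compound 3 (0.13 log units; within the scatter), with no direction to be read into it. Compound 3 is therefore expected to give around 900 nM in this assay, with a plausible range from 400 nM to 2000 nM.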

Compound 3, half-maximal inhibitory concentration: 950 nM
Beside the measured number, compound 3's estimate is 1.1-fold (0.02 log units) below it; the range from low to high includes it.
By their numbers in this assay, from the lowest: compounds 2, 3 and 1 (each within the scatter of the next).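

In this assay the steps of a 1.4-fold higher number from compound 2 to compound 3 (0.15 log units; within the scatter) and a 1.2-fold lower number from compound 1 to compound 3 (0.06 log units; within the scatter) both stay within the scatter, so methyl, chloro and fluoro at this place, para to a large group, cannot be put in any order. Among these compounds, the earlier compounds offered only one pair of groups, which could have been a chance match; a third group now gives the same flat picture, and across these three compounds this position tolerates an exchange of one small group for another without a readable shift in the number. No measurement is available that explains why the three read alike, and the data tie this result to no particular feature of the groups.

From the compounds shown here alone, all three groups are small, so it remains open whether something of a different kind at this place, such as an amine, a carboxylic acid or a longer chain, would also stay within the scatter. The three compounds also share everything else in their structure, so they say nothing about how changes elsewhere on the shared core would read.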